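The source may report more compounds than this note shows. Statements on the series, on what has been measured and on what is new or still open speak of the compounds shown alone.

Of the compounds shown here, three have been measured in a functional assay on PC-3 cells (Homo sapiens); a higher number here means a weaker inhibitor of growth, a lower number a stronger inhibitor of growth. Compound 1 `Oc1cc(-c2ccc(Cl)cc2)nc2ncccc12` gives 47900 nM. Compound 3 `Cc1cnc2nc(-c3ccc(Cl)cc3)cc(O)c2c1` gives 1150 nM; the change hydrogen in place of methyl on an aromatic carbon costs a 42-fold higher number from compound 3 to compound 1 (1.62 log units; beyond the scatter). Compound 2 `COc1cccc(-c2cc(O)c3c(C)cc(C)nc3n2)c1` gives 309 nM, the lowest of the three; the difference between the core of compound 2 and that of compound 3 is not broken down here. Compound 4 `COc1cccc(-c2cc(O)c3c(C)ccnc3n2)c1` has not been measured. It differs from compound 2 by hydrogen in place of methyl on an aromatic carbon, the same kind of change as from compound 3 to compound 1, though not the same: here the place is next to the ring nitrogen and meta to a methyl group, there it was two atoms from the ring nitrogen. A loss is expected for compound 4, estimated at a 13-fold higher number from compound 2 to compound 4 (1.11 log units; beyond the scatter), because the like change cost a 42-fold higher number from compound 3 to compound 1 (1.62 log units; beyond the scatter). Compound 4 is therefore estimated at 4000 nM, expected to fall between 800 nM and 20000 nM.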

Compound 4, concentration for 50% growth inhibition: 26.3 nM
Beside the measured number, compound 4's estimate is 150-fold (2.18 log units) above it; measured number below the stated range.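

In this assay, hydrogen in place of methyl on an aromatic carbon gives a 12-fold lower number from compound 2 to compound 4 (1.07 log units; beyond the scatter), so the change does not carry over from one core to the other with its direction intact: the same change on two cores in this assay, a 42-fold higher number (1.62 log units; beyond the scatter) from compound 3 to compound 1 and a 12-fold lower number (1.07 log units; beyond the scatter) from compound 2 to compound 4, 490-fold (2.69 log units) apart, beyond the scatter of two such steps

The two steps stand at different places on different cores, and the pair cannot tell whether the place or the rest of the core decides the outcome. Two steps give no rule for a further core, and they do not explain the reversal.

Left open is whether an amine or a longer chain next to the ring nitrogen would keep the low number of compound 4. Also open, going by these compounds, is what the methyl group that compound 4 retains contributes.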